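The source may report more compounds than this note shows. Statements on the series, on what has been measured and on what is new or still open speak of the compounds shown alone.

Compound 3 `O=C(/C=C\Nc1ccc(F)cc1)c1nc(-c2ccc(C(F)(F)F)cc2)n2ccccc12` carries a 4-fluorophenyl group on the amine nitrogen of the shared core. In a functional assay on BT-474 cells (Homo sapiens) for cytotoxicity, read by MTT assay, with a stated time of 48 h (on this read-out higher numbers stand for weaker inhibition and lower numbers for stronger inhibition), compound 3 reaches only a limit, > 30000 nM, and so stands at the limit of > 30000 nM in this assay, at which 1 of the 3 values shown sits. Its two measured neighbours give numbers: compound 1 `O=C(/C=C\Nc1ccc2[nH]ccc2c1)c1nc(-c2ccc(C(F)(F)F)cc2)n2ccccc12`, with a 1H-indol-5-yl group in the same place, gives 5190 nM in this assay, and compound 2 `O=C(/C=C\Nc1ccc(Cl)cc1)c1nc(-c2ccc(C(F)(F)F)cc2)n2ccccc12`, with a 4-chlorophenyl group, gives 3820 nM in this assay. The steps of an at least 5.7-fold higher number from compound 1 to compound 3 (0.76 log units; beyond the scatter) and an at least 7.8-fold higher number from compound 2 to compound 3 (0.89 log units; beyond the scatter) both run toward weaker inhibition, while a 1.4-fold lower number from compound 1 to compound 2 (0.13 log units; within the scatter) is within the scatter. Compound 4 `O=C(/C=C\Nc1cnc2ccccc2c1)c1nc(-c2ccc(C(F)(F)F)cc2)n2ccccc12` is not yet measured; the change from compound 3 is quinolin-3-yl in place of 4-fluorophenyl on an amine nitrogen. This brings in a bicyclic aromatic group, as compound 1 has, and removes the fluorine that set compound 3 apart from compound 2. Given that compound 1 gives 5190 nM with a bicyclic aromatic group in this place, compound 4 is expected to show a step of an at least 4.2-fold lower number from compound 3 to compound 4 (0.63 log units; beyond the scatter) in this assay toward stronger inhibition. The estimate for compound 4 in this assay is 7000 nM, with a range from 1500 nM to 40000 nM.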

Compound 4, half-maximal inhibitory concentration: > 30000 nM
Compound 4 ended at the assay's limit (the forecaster's own chance of this, stated with the estimate: 25%); middle value at least 4.2-fold (0.63 log units) from the limit.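

In this assay compound 4 gives only a limit of the assay, not a number: the limit of > 30000 nM in this assay, at which 2 of the 4 values shown sit.

A bicyclic aromatic group on the amine nitrogen is thus not enough on its own to give a readable value: quinolin-3-yl in place of 1H-indol-5-yl gives an at least 5.7-fold higher number from compound 1 to compound 4 (0.76 log units; beyond the scatter), and quinolin-3-yl in place of 4-chlorophenyl gives an at least 7.8-fold higher number from compound 2 to compound 4 (0.89 log units; beyond the scatter). The step between compound 3 and compound 4 cannot be read, so these two groups can only be said to share the limit.

The compounds shown leave open whether the ring nitrogen of quinolin-3-yl matters, which a naphthyl group on the same amine nitrogen would test. They also leave open whether a 4-bromophenyl group would read like 4-chlorophenyl or fall to the limit like 4-fluorophenyl.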